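The source may hold more compounds than are shown below. What is called first, only, known or untested is meant among the compounds shown, and "the series" means these compounds.

Measured in a physicochemical assay for solubility; a lower number here means a less soluble compound, a higher number a more soluble compound:
- Compound 1 `COc1ccc(-n2cnc3cnc(Nc4cccc(NC(C)=O)c4)cc32)cc1OC` gives > 200000 nM (a limit, not a number)
- Compound 2 `COc1ccc(-n2cnc3cnc(-c4cccc(NC(C)=O)c4)cc32)cc1OC` gives 146000 nM (a number)
- Compound 3 `COc1ccc(-n2cnc3cnc(-c4ccccc4C)cc32)cc1OC` gives > 200000 nM (a limit, not a number)

Compound 3 has no numerical value in this assay and stands at the limit of > 200000 nM in this assay, at which 2 of the 3 values shown sit, so the starting point of this step is a limit. Among the compounds with values here, compound 2 is the only one of the three with a number, and no measured pair isolates a single structural change.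

Compound 4 `COc1ccc(-n2cnc3cnc(-c4cc(F)ccc4C)cc32)cc1OC` turns the 2-methylphenyl of compound 3 into 5-fluoro-2-methylphenyl. The change is fluoro in place of hydrogen on an aromatic carbon, para to a methyl group. The measured compounds give no direct guide to what this does in this assay, so no shift beyond the usual scatter is expected, in either direction. The expectation leans on compound 3 at > 200000 nM, which is a limit. The estimated change is an at least 1.0-fold lower number from compound 3 to compound 4 (0.02 log units; that floor lies within the scatter), which would lie within the scatter. Compound 4 is expected at 190000 nM, with an estimated range of 100000 nM to 300000 nM, and it may also be reported only as a limit.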

Compound 4, solubility: 157000 nM
For compound 4 the middle estimate is 1.2-fold (0.08 log units) above the measured one; low and high end bracket the measured number.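

In this assay, fluoro in place of hydrogen on an aromatic carbon, para to a methyl group, gives an at least 1.2-fold lower number from compound 3 to compound 4 (0.10 log units; that floor lies within the scatter). This is the first step among the compounds shown that isolates a single change, and it gives the first reading at this place on the ring, where a single fluorine atom replaces a hydrogen atom on the 2-methylphenyl group. Compound 3 has only a limit and not a number, so the step is known only as a floor, and how far it may reach beyond that floor cannot be read: the limit of > 200000 nM in this assay, at which 2 of the 4 values shown sit.

Going by these compounds, whether a different group at this same place, such as an amine or a carboxylic acid, would give a step beyond the scatter in this assay remains open. Also open, on these data alone, is whether fluoro would give a step of similar size on compound 2, which, unlike compound 3, has a number as its starting point.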